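The source may report more compounds than this note shows. Statements on the series, on what has been measured and on what is new or still open speak of the compounds shown alone.

The study compares four compounds that share a fused core and differ in the amine attached to it and in a single aromatic substituent. Compound 2 `CCNCC1CCN(c2cc3c(cc2F)c(=O)c(C(=O)O)cn3NC)C1` carries a 3-((ethylamino)methyl)pyrrolidin-1-yl group. In a functional assay on V79 cells (Cricetulus griseus) for cytotoxicity, read by colony formation (a higher number here means a weaker inhibitor, a lower number a stronger inhibitor), compound 2 reaches only a limit of the assay, > 500 ug/mL. Compound 1 `CCNCC1CCN(c2c(F)cc3c(=O)c(C(=O)O)cn(NC)c3c2F)C1` differs from compound 2 by fluoro in place of hydrogen on an aromatic carbon. In this assay compound 1 likewise gives only a limit, > 500 ug/mL. The step that the two limits leave unreadable from compound 2 to compound 1 therefore cannot be read, because of the limit of > 500 ug/mL in this assay, at which 2 of the 3 values shown sit. Compound 3 `NC1CCN(c2cc3c(cc2F)c(=O)c(C(=O)O)cn3C2CC2)CC1` carries a 4-aminopiperidin-1-yl group; the difference between its core and that of compound 2 is not broken down here. In this assay, within the data shown here, compound 3 gives 230 ug/mL, the only number among the three. Compound 4 `NC1CCN(c2c(F)cc3c(=O)c(C(=O)O)cn(C4CC4)c3c2F)CC1` is yet to be measured; it differs from compound 3 by fluoro in place of hydrogen on an aromatic carbon. This is the same kind of change as that from compound 2 to compound 1, though here the entering fluoro group sits ortho to a 4-aminopiperidin-1-yl group rather than ortho to a 3-((ethylamino)methyl)pyrrolidin-1-yl group. Among the measured compounds shown here, since the earlier step is unreadable, the only anchor is compound 3 with 230 ug/mL. Compound 4 is expected to stand near that anchor, the expected step being a 1.2-fold higher number from compound 3 to compound 4 (0.09 log units; within the scatter). Compound 4 is estimated at 280 ug/mL, with a range from 140 ug/mL to 560 ug/mL.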

Compound 4, half-maximal inhibitory concentration: 23 ug/mL
Beside the measured number, compound 4's estimate is 12-fold (1.09 log units) above it, and the stated range ends above it.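

In this assay, fluoro in place of hydrogen on an aromatic carbon, ortho to a 4-aminopiperidin-1-yl group, gives a 10-fold lower number from compound 3 to compound 4 (1.00 log units; beyond the scatter) and so has a clear effect on the number in this one pair. The same change on the core of compound 2, where the amine is a 3-((ethylamino)methyl)pyrrolidin-1-yl group, cannot be read, because compound 2 and compound 1 both give only a limit of the assay: the limit of > 500 ug/mL in this assay, at which 2 of the 4 values shown sit. The series therefore does not show that the step carries from one core to the other: it neither confirms nor rules out a step of like size there, and a single readable pair cannot establish a pattern.

The compounds shown leave open whether chloro or methoxy on the same aromatic carbon of compound 3 would give a step of similar size to that of fluoro. They also leave open how the step would look with an ester in place of the carboxylic acid, or on a core with a different amine whose values fall clear of the limit.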